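A few compounds are considered here, and "the series" means these few. Any claim that something is new, unique, unknown or untested is made for them only; others in the source may bear on it.

Measured compounds:
- compound 1, `COc1cc(N2C(=O)[C@H](Oc3ccccc3)[C@H]2c2ccc(C#N)cc2)cc(OC)c1OC`, 168000 nM
- compound 2, `COc1ccc([C@@H]2[C@H](Oc3ccccc3)C(=O)N2c2cc(OC)c(OC)c(OC)c2)cc1[N+](=O)[O-]`, 69000 nM
- compound 3, `COc1ccc([C@@H]2[C@@H](Oc3ccccc3)C(=O)N2c2cc(OC)c(OC)c(OC)c2)cc1[N+](=O)[O-]`, 4100 nM

All three were tested in a functional assay on MCF7 cells (Homo sapiens) for antiproliferative activity, read by MTT assay, with stated times of 24 h and 72 h; a lower number here means a stronger inhibitor, a higher number a weaker inhibitor. Compound 2 gives the second highest number of the three, with compound 1 nearest at 168000 nM and compound 3 furthest at 4100 nM.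

Compound 4 is `COc1cc(N2C(=O)[C@@H](Oc3ccccc3)[C@H]2c2cc(N)c(OC)c(O)c2)cc(OC)c1OC`. Relative to compound 2 the change is a group of 10 heavy atoms (7 carbon, 1 nitrogen, 2 oxygen; one six-membered aromatic ring of carbon only) in place of a group of 11 heavy atoms (7 carbon, 1 nitrogen, 3 oxygen; one six-membered aromatic ring of carbon only), on a saturated ring carbon. Its configuration is that of compound 2, not of compound 3.

Two measured steps exist. The step of a 41-fold lower number from compound 1 to compound 3 (1.61 log units; beyond the scatter) shows that swapping the aryl group on this carbon can move the number a great deal, though with a different pair of aryl groups and in the other configuration. The step of a 17-fold lower number from compound 2 to compound 3 (1.23 log units; beyond the scatter) is large because of the fact that compounds 2 and 3 differ only in the configuration as drawn; it says nothing about the aryl swap. Within the data shown here, no measured step covers the change from compound 2 to compound 4 directly, so only a loose expectation is possible: the estimated step is a 1.7-fold lower number from compound 2 to compound 4 (0.24 log units; within the scatter), within a broad range. Compound 4 is expected to give about 40000 nM, between 8000 nM and 200000 nM.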

Compound 4, half-maximal inhibitory concentration: 8800 nM
Compound 4: middle estimate off by 4.5-fold (0.66 log units), on the high side; the measured number falls inside the stated range.
By their numbers in this assay, from the lowest: compound 3; then compound 4; then compound 2; then compound 1.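

With the configuration held as in compound 2, replacing 4-methoxy-3-nitrophenyl with the group of 10 heavy atoms gives a 7.8-fold lower number from compound 2 to compound 4 (0.89 log units; beyond the scatter), so the aryl group alone changes the result. The earlier aryl swap, a 41-fold lower number from compound 1 to compound 3 (1.61 log units; beyond the scatter), involved a different pair of groups in the other configuration, whereas this step shows that the same position also responds to its aryl group in the configuration of compound 2. Nothing given here explains why this swap lowers the number.

The entering group differs from the leaving one in more than one way, including 2 hydrogen-bond donors against 0, so the part of the group that matters cannot be singled out. Also open, from the compounds shown here alone, are how this group behaves in the configuration of compound 3 and what a carboxylic acid or a trifluoromethyl group on this aryl ring would give.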